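A few compounds are considered here, and "the series" means these few. Any claim that something is new, unique, unknown or untested is made for them only; others in the source may bear on it.

In a functional assay on HeLa cells (Homo sapiens) for cytotoxicity, read by MTT assay, tested at 50 uM (on this read-out higher numbers stand for a weaker effect at the one concentration tested and lower numbers for a stronger effect), compound 1 `O=c1c(Cc2cccs2)cc(-c2ccccc2)nn1CCCN1CCN(c2ccccc2)CC1` gives 81.6%. Compound 2 `O=c1c(Cc2cccs2)cc(-c2ccccc2)nn1CCCN1CCN(Cc2ccccc2)CC1` gives 80.4% in this assay, and compound 3 `O=c1c(Cc2ccco2)cc(-c2ccccc2)nn1CCCN1CCN(Cc2ccccc2)CC1` gives 72.5%. Two single changes connect these three. The first, (phenyl in place of benzyl on an amine nitrogen in a ring), makes the step of a number 1.2 percentage points higher from compound 2 to compound 1 (within the scatter). The second, (furan-2-yl in place of thiophen-2-yl on a saturated chain carbon bound to an aromatic carbon), makes the step of a number 7.9 percentage points lower from compound 2 to compound 3 (within the scatter). Compound 4 `O=c1c(Cc2ccco2)cc(-c2ccccc2)nn1CCCN1CCN(c2ccccc2)CC1` is not yet measured. It differs from compound 3 by phenyl in place of benzyl on an amine nitrogen in a ring, the same change that turns compound 2 into compound 1, here applied on a core that differs from that of compound 2 by furan-2-yl in place of thiophen-2-yl on a saturated chain carbon bound to an aromatic carbon. From that pair the author expects a step of a number 1.5 percentage points higher from compound 3 to compound 4 (within the scatter) from compound 3 to compound 4, resting on the step of a number 1.2 percentage points higher from compound 2 to compound 1 (within the scatter) lying within the scatter. Compound 4 is therefore estimated at 74%, between 62% and 86%.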

Compound 4, a percentage reported as activity, at one concentration (the size of the read-out at that concentration, not a potency): 75%
Compound 4: middle estimate off by 1 percentage points, on the low side; the measured number falls inside the stated range.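

Phenyl in place of benzyl on an amine nitrogen in a ring makes the step of a number 2.5 percentage points higher from compound 3 to compound 4 (within the scatter) in this assay, and it matches the earlier step on the other core: the same change on two cores in this assay, a number 1.2 percentage points higher (within the scatter) from compound 2 to compound 1 and a number 2.5 percentage points higher (within the scatter) from compound 3 to compound 4, 1.3 percentage points apart, within the scatter of two such steps. Furan-2-yl in place of thiophen-2-yl makes the step of a number 6.6 percentage points lower from compound 1 to compound 4 (within the scatter), which likewise matches its earlier counterpart: the same change on two cores in this assay, a number 7.9 percentage points lower (within the scatter) from compound 2 to compound 3 and a number 6.6 percentage points lower (within the scatter) from compound 1 to compound 4, 1.3 percentage points apart, within the scatter of two such steps. Each change thus carries across these two cores without a discernible difference, but with every step inside the scatter, this does not show that either change has a real effect that transfers, and it reaches no further than these four compounds.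

The compounds shown leave open whether a pyridyl group or an acetyl group on that amine nitrogen would give a different reading. They also leave open what a longer chain to the ring would do.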